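Replacing isopropylsulfanyl with methylamino: working notes

A few compounds are considered here, and "the series" means these few. Any claim that something is new, unique, unknown or untested is made for them only; others in the source may bear on it.

Of the compounds shown here, three have been measured in a functional assay on MV4-11 cells (Homo sapiens) for inhibition, read by resazurin assay, with a stated time of 72 h; on this read-out lower numbers stand for stronger inhibition of growth and higher numbers for weaker inhibition of growth: compound 1 (`CCn1cc(-c2ccnc(Nc3ccc(OC)cc3OC)n2)c2ccccc21`) gives (3590 nM), compound 2 (`COc1ccc(Nc2nccc(-c3sc(SC(C)C)nc3C)n2)c(OC)c1`) gives (5670 nM) and compound 3 (`COc1ccc(N(C)c2nccc(-c3cn(C)c4ccccc34)n2)c(OC)c1`) gives (2000 nM). Compound 2 stands within the scatter of compound 1, while the gap between compound 2 and compound 3 lies beyond the scatter, with compound 3 on the lower number.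

The next compound is compound 4 (`CNc1nc(C)c(-c2ccnc(Nc3ccc(OC)cc3OC)n2)s1`), which carries methylamino in place of isopropylsulfanyl on an aromatic carbon. Among the measured compounds shown here, no measured pair isolates this change. For the measured compounds named here, the only guide is the range spanned by the measured compounds, from compound 3 (2000 nM) to compound 2 (5670 nM). A modest move toward a lower number is expected in this assay, and a step within the scatter would not be a surprise. The expected size is estimated as (a 2.3-fold lower number from compound 2 to compound 4 (0.36 log units; beyond the scatter)). Compound 4 is estimated at 2500 nM (expected range 700 nM to 8000 nM).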

Compound 4, concentration for 50% growth inhibition: 300 nM
Compound 4: middle estimate off by 8.3-fold (0.92 log units), on the high side; the measured number lies below the stated range.
By their numbers in this assay, from the lowest: compound 4; then compounds 3, 1 and 2 (each within the scatter of the next, the first and the last beyond it).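

Among the compounds shown here, the group on the aromatic carbon next to the ring nitrogen and next to the ring sulfur has a strong bearing on growth inhibition in this assay and methylamino in place of isopropylsulfanyl gives a 19-fold lower number from compound 2 to compound 4 (1.28 log units; beyond the scatter) as the first one-place step. The change replaces a larger group with no hydrogen-bond donor by a smaller one with a hydrogen-bond donor, and this single step cannot separate those two differences. No measurement shown here accounts for the size of the step.

Dimethylamino at this position would test whether the hydrogen on the methylamino nitrogen matters, while amino and ethylamino would show how the result follows the size of the group. Going by these compounds, it also remains open whether the methyl group on the same ring contributes to the result.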